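This account rests on a few compounds, and the source may have more. Where it says the series, first, only, none or still open, it means among the compounds named here.

In a functional assay on T98G cells (Homo sapiens) for cytotoxicity, read by MTT assay, with a stated time of 48 h (a lower number here means a stronger inhibitor, a higher number a weaker inhibitor), compound 2 `C/C(=N/NC(=S)Nc1ccccc1)c1ccccn1` gives 6.81 nM, the lower of the two numbers available and beyond the scatter from compound 1 `CC(=NNC(=S)Nc1cccc([N+](=O)[O-])c1)c1ccccn1`, which gives 140 nM. Compound 3 `C/C(=N/NC(=S)Nc1cccc([N+](=O)[O-])c1)c1ccccn1` has not yet been measured. It departs from compound 2 by a single change, nitro in place of hydrogen on an aromatic carbon: a nitro in place of hydrogen on an aromatic carbon, meta to a large group. For the measured compounds named here, no measured pair isolates this change, so its size can only be judged indirectly. The best guide is compound 1, which also carries the nitro and gives 140 nM. A step beyond the scatter towards a higher number, meaning a weaker inhibitor, is therefore expected, estimated as a 16-fold higher number from compound 2 to compound 3 (1.21 log units; beyond the scatter) in this assay. For compound 3 the expected value is 110 nM, with an estimated range of 35 nM to 320 nM.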

Compound 3, half-maximal inhibitory concentration: 140 nM
Compound 3: the middle estimate sits 1.3-fold (0.10 log units) below what was measured; the measured number falls inside the stated range.
By their numbers in this assay, from the lowest: compound 2; then compounds 1 and 3 (each within the scatter of the next).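

In this assay, the nitro, meta to a large group, now has a measured pair of its own, and replacing hydrogen with it gives a large loss, a 21-fold higher number from compound 2 to compound 3 (1.31 log units; beyond the scatter). The other step, no change at the digits printed from compound 1 to compound 3 (within the scatter), shows that drawing the double bond as Z leaves the number as it was, so the value of compound 1 offers the same reading of the nitro as the defined structure does. The two compounds have the same atoms and bonds, and only one thing separates them: the fact that one of compounds 1 and 3 is drawn with a defined configuration and the other without, at the place where they differ

The compounds shown carry only hydrogen or nitro at this place, so whether a nitrile, a methoxy group or an amine there would cost as much remains open. They also leave open how a nitro would fare elsewhere on the ring.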